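The source may hold more compounds than are shown below. What is called first, only, known or untested is meant among the compounds shown, and "the series" means these compounds.

The measured compounds and their values in a functional assay on HCT-116 cells (Homo sapiens) for inhibition, read by colorimetric assay, with a stated time of 3 days; on this read-out higher numbers stand for weaker inhibition and lower numbers for stronger inhibition:

compound 1, `O=C(CCCCCCNC(=O)C(O)(O)C(F)(F)F)Nc1nc2ccc(Br)cc2s1`, 10300 nM
compound 2, `C/C(=N\O)C(=O)NCCCCCC(=O)Nc1ccccc1`, a limit of > 100000 nM
compound 3, `COc1ccc2nc(NC(=O)CCCCCCNC(=O)C(O)(O)C(F)(F)F)sc2c1`, 7560 nM

Compound 1 and compound 3 share a core and differ in one substituent only: a 1.4-fold lower number from compound 1 to compound 3 (0.13 log units; within the scatter). Compound 2 has a smaller core and stands apart from both of them. In this assay compound 2 gives no number, only the limit (the limit of > 100000 nM in this assay, at which 1 of the 3 values shown sits), so it can only be said that compound 2 sits at the weak end of what this assay reports.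

Compound 4, `CC(=O)C(=O)NCCCCCCC(=O)Nc1ccccc1`, differs from compound 2 in one place: a group of 7 heavy atoms (4 carbon, 1 nitrogen, 2 oxygen; no ring) in place of a group of 7 heavy atoms (3 carbon, 2 nitrogen, 2 oxygen; no ring), on a saturated chain carbon, five bonds along the chain from a carbonyl carbon. Within the data shown here, none of the measured steps touches this part of the chain; the only step measured, a 1.4-fold lower number from compound 1 to compound 3 (0.13 log units; within the scatter), sits on an aromatic carbon of a different core and lies within the scatter, so it carries nothing over to the chain. Nothing measured points to a gain or a loss from this change. The step of a number no higher from compound 2 to compound 4 (the limit leaves the size open) is therefore expected to be none beyond the scatter. Compound 4 is expected at 100000 nM, between 30000 nM and 300000 nM, and most likely reported again only as a limit.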

Compound 4, half-maximal inhibitory concentration: > 100000 nM
Compound 4: only a limit was reported; the forecaster's own chance of this, stated with the estimate: 70%; the middle value lies on the limit itself.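

No step can be read from compound 2 to compound 4, because each is reported only as a limit and not as a number: the limit of > 100000 nM in this assay, at which 2 of the 4 values shown sit.

The compounds shown leave open how strongly compound 2 and compound 4 actually inhibit, and whether the change between them has any effect.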